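The source may report more compounds than this note shows. Statements on the series, on what has been measured and on what is new or still open speak of the compounds shown alone.

Of the compounds shown here, two have been measured in a functional assay on RXF 393 cells (Homo sapiens) for inhibition, read by sulforhodamine B assay, with a stated time of 48 h; a lower number here means a stronger inhibitor of growth, a higher number a weaker inhibitor of growth. Within the data shown here, compound 1 `Nc1cc(N)c2nc(-c3ccccc3)c(NCc3ccc(F)cc3)nc2c1` gives 12300 nM, the highest of the two numbers so far. Compound 2 `COc1ccc(CNc2nc3cc(N)cc(N)c3nc2-c2ccccc2)cc1` gives 5370 nM. Among the measured compounds shown here, the single step between measured compounds, a 2.3-fold lower number from compound 1 to compound 2 (0.36 log units; beyond the scatter), is modest and concerns only the substituent on the benzyl ring.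

Compound 3 `Nc1cc(N)c2nc(-c3ccccc3)c(Sc3ccc(Cl)c(Cl)c3)nc2c1` is not yet measured. It differs from compound 1 in one place: (3,4-dichlorophenyl)sulfanyl in place of (4-fluorobenzyl)amino on an aromatic carbon. This exchange removes the whole (4-fluorobenzyl)amino group rather than its substituent alone, so the step from compound 1 to compound 2 bears on it only in showing that alterations on this side of the shared core have moved this assay by a modest amount. For the measured compounds named here, no measured pair covers a (3,4-dichlorophenyl)sulfanyl group or any change of the linking atom, and the direction of the coming step cannot be read from the data.

Compound 3 is therefore expected near 9000 nM, with a wide range from 2000 nM to 40000 nM. That estimate corresponds to a 1.4-fold lower number from compound 1 to compound 3 (0.14 log units; within the scatter), an expectation of no step beyond the scatter, open to either direction.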

Compound 3, concentration for 50% growth inhibition: 12300 nM
Beside the measured number, compound 3's estimate is 1.4-fold (0.14 log units) below it; the range from low to high includes it.
By their numbers in this assay, from the lowest: compound 2; then compounds 1 and 3 (each within the scatter of the next).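

In this assay, replacing the whole (4-fluorobenzyl)amino group with (3,4-dichlorophenyl)sulfanyl gives no change at the digits printed from compound 1 to compound 3 (within the scatter), whereas the earlier step, a 2.3-fold lower number from compound 1 to compound 2 (0.36 log units; beyond the scatter), changed only the substituent on the benzyl ring. At this position, next to the ring nitrogen and ortho to the phenyl group, a full exchange of the group therefore leaves the number in place, even though the group that leaves carries 1 hydrogen-bond donor and the group that enters carries 0 hydrogen-bond donors. No supporting measurement is available to explain why the number holds across this exchange.

The exchange alters the linking atoms and the ring substituents in a single step, and these compounds cannot show whether each change alone is silent in this assay or whether separate effects cancel. Unsubstituted phenylsulfanyl and (4-fluorophenyl)sulfanyl would separate those two changes, while a morpholine or a carboxylic acid at this position would test how far the insensitivity extends beyond groups carrying an aromatic ring.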